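Methoxycarbonyl to Carboxy on Two Related Fused Cores

The compounds below may be only part of what the source reports. "The series", "measured", "known", "first", "only" and "open" are said of these compounds alone.

This account concerns four compounds that share a fused ring system carrying a benzoyl group, and it follows one small change across two pairs of them. Compound 1 `COC(=O)c1ccc2c(C(=O)c3ccccc3)cc(C(=O)c3ccccc3)c-2cc1` bears a methoxycarbonyl group and a second benzoyl group, and compound 2 `O=C(O)c1ccc2c(C(=O)c3ccccc3)cc(C(=O)c3ccccc3)c-2cc1` differs from it only in the change (hydrogen in place of methyl on an oxygen next to a carbonyl group). In an assay on cells for displacement of a labelled ligand from Orexin/Hypocretin receptor type 1 (Homo sapiens), read by scintillation counting, with stated times of 10 min and 90 min, tested at 10 uM (a lower number here means less inhibition, a higher number more inhibition at the concentration tested (going by the name of the read-out)), compound 1 gives -10.6%, and in this assay compound 2 gives -10.4%; the step of a number 0.2 percentage points higher from compound 1 to compound 2 (within the scatter) is as small as steps of this kind get.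

Compound 3 `CCOc1ccc(-c2cc(C(=O)c3ccccc3)c3ccc(C(=O)OC)ccc2-3)cc1` keeps the methoxycarbonyl group of compound 1 but differs from it in the change (4-ethoxyphenyl in place of benzoyl on an aromatic carbon). In this assay compound 3 gives 8.4%, and the step of a number 19 percentage points higher from compound 1 to compound 3 (beyond the scatter) makes compound 3 the compound with the highest number among the three measured, standing beyond the scatter from both compound 1 and compound 2.

Compound 4 `CCOc1ccc(-c2cc(C(=O)c3ccccc3)c3ccc(C(=O)O)ccc2-3)cc1` has not yet been measured. It differs from compound 3 in the change (hydrogen in place of methyl on an oxygen next to a carbonyl group), which is the same change, at the same place, as that from compound 1 to compound 2. The step that is expected from compound 3 to compound 4, a number 0.2 percentage points higher from compound 3 to compound 4 (within the scatter), is set to match the earlier one, because a number 0.2 percentage points higher from compound 1 to compound 2 (within the scatter) showed that this change left the read-out essentially where it was on the core of compound 1. On that basis compound 4 is estimated at 8.6% in this assay, expected to fall between -6% and 22%. Whether the core of compound 3 treats the change in the same way remains to be seen.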

Compound 4, a percentage reported as inhibition, at one concentration (the size of the read-out at that concentration, not a potency): -24%
Compound 4: middle estimate off by 32.6 percentage points, on the high side; the whole stated range lies above it.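

In this assay the change from methoxycarbonyl to carboxy did not carry over from one core to the other, and the new step, a number 32.4 percentage points lower from compound 3 to compound 4 (beyond the scatter), stands apart from the earlier one: the same change on two cores in this assay, a number 0.2 percentage points higher (within the scatter) from compound 1 to compound 2 and a number 32.4 percentage points lower (beyond the scatter) from compound 3 to compound 4, 32.6 percentage points apart, beyond the scatter of two such steps. Read the other way round, the change from benzoyl to 4-ethoxyphenyl on an aromatic carbon also gave different results in the two pairs, with the carboxy pair showing a number 13.6 percentage points lower from compound 2 to compound 4 (beyond the scatter), against an upward step in the methoxycarbonyl pair: the same change on two cores in this assay, a number 19 percentage points higher (beyond the scatter) from compound 1 to compound 3 and a number 13.6 percentage points lower (beyond the scatter) from compound 2 to compound 4, 32.6 percentage points apart, beyond the scatter of two such steps. Among the compounds shown here, this shows that, across these four compounds, the outcome of either change depends on the other group present, but it does not show why, and with only one pair on each core it gives no rule for any further core.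

The compounds shown leave open whether an ethyl ester, an amide or a nitrile in place of the methoxycarbonyl group would follow compound 3 or compound 4 on this core. They also leave open whether the gap between the two cores depends on the ethoxy group itself, which a plain phenyl or a longer alkoxy chain on that aromatic carbon could test.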